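Same Amine Ring Swap, Tried on a Different Tail

A few compounds are considered here, and "the series" means these few. Any claim that something is new, unique, unknown or untested is made for them only; others in the source may bear on it.

Three measured compounds share one core and differ only in the tail on its outer ring. Compound 2 `COc1cc(OC)c2c(=O)cc(-c3ccc(OCC(O)CN(C)C)cc3)oc2c1` and compound 1 `COc1cc(OC)c2c(=O)cc(-c3ccc(OCC(O)CN4CCCC4)cc3)oc2c1` both carry an ether-linked tail ending in an amine. In a functional assay (Homo sapiens) for antiproliferative activity, read by resazurin assay, with a stated time of 48 h, tested at 10 uM (on this read-out lower numbers stand for a weaker effect and higher numbers for a stronger effect at the one concentration tested), compound 2 gives 60%, while compound 1 gives 37%. Among the compounds with values here, the single change between them is pyrrolidin-1-yl in place of dimethylamino on a saturated chain carbon, two bonds along the chain from an oxygen on a saturated carbon, and that change made a number 23 percentage points lower from compound 2 to compound 1 (beyond the scatter).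

Compound 3 `COc1cc(OC)c2c(=O)cc(-c3ccc(NCCN(C)C)cc3)oc2c1` keeps the dimethylamino end but changes the link to the ring: (2-(dimethylamino)ethyl)amino in place of 3-(dimethylamino)-2-hydroxypropoxy on an aromatic carbon. In this assay compound 3 gives 60%, so the step is no change at the digits printed from compound 2 to compound 3 (within the scatter), whereas the step is a number 23 percentage points higher from compound 1 to compound 3 (beyond the scatter).

Compound 4 `COc1cc(OC)c2c(=O)cc(-c3ccc(NCCN4CCCC4)cc3)oc2c1` has not yet been measured. It differs from compound 3 by pyrrolidin-1-yl in place of dimethylamino on a saturated chain carbon, two bonds along the chain from a nitrogen on an aromatic ring. Within the data shown here, this is the same kind of change as the one from compound 2 to compound 1, not the same change: there the carbon carrying the amine sat two bonds along the chain from an oxygen on a saturated carbon, here it sits two bonds along the chain from a nitrogen on an aromatic ring. Among the measured compounds shown here, only one earlier example of this swap exists, so the expectation leans on it alone. The step is expected to be a number 20 percentage points lower from compound 3 to compound 4 (beyond the scatter) because the earlier swap gave a number 23 percentage points lower from compound 2 to compound 1 (beyond the scatter). Compound 4 is therefore estimated at 40%, with a range from 22% to 58%.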

Compound 4, a percentage reported as inhibition, at one concentration (the size of the read-out at that concentration, not a potency): 51%
Compound 4: the middle estimate sits 11 percentage points below what was measured; low and high end bracket the measured number.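

Set side by side in this assay, the swap of dimethylamino for pyrrolidin-1-yl on the two tails gives steps that cannot be told apart: the same change on two cores in this assay, a number 23 percentage points lower (beyond the scatter) from compound 2 to compound 1 and a number 9 percentage points lower (within the scatter) from compound 3 to compound 4, 14 percentage points apart, within the scatter of two such steps

Taken alone, the swap on the nitrogen-linked tail gives a number 9 percentage points lower from compound 3 to compound 4 (within the scatter), so this pair does not repeat the clear drop seen on the ether-linked tail, although the gap between the two steps does not show that the tail's link matters. Two pairs cannot show that the swap carries over unchanged from one core to another or that it depends on the core, and the other two new steps, a number 9 percentage points lower from compound 2 to compound 4 (within the scatter) and a number 14 percentage points higher from compound 1 to compound 4 (beyond the scatter), each replace a whole tail, so neither isolates the amine end.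

The compounds shown leave open how a piperidine or a morpholine at the chain end would compare with dimethylamino and pyrrolidin-1-yl, and whether a longer chain would change the size of the swap. On these data alone, each number also comes from a single concentration, so how these compounds compare across a range of concentrations remains open.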